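Benzyl for sec-butyl on the aromatic nitrogen of compound 1

The source may hold more compounds than are shown below. What is called first, only, known or untested is meant among the compounds shown, and "the series" means these compounds.

Compound 1 `CCC(C)n1cnc2c(NCc3ccc(C(=O)Nc4ccccc4N)cc3)nc(Cl)nc21`: 67.7%
Compound 2 `Nc1ccccc1NC(=O)c1ccc(Cn2cnc3c(Nc4ccccc4)nc(Cl)nc32)cc1`: 77.8%
Compound 3 `Nc1ccccc1NC(=O)/C=C/c1ccc(Cn2cnc3c(NC4CCCCC4)nc(Cl)nc32)cc1`: 24.9%

Of the compounds shown here, three have been measured in a functional assay on NCI-H460 cells (Homo sapiens) for antiproliferative activity, read by CCK-8 assay, with a stated time of 72 h, tested at 8 uM; on this read-out higher numbers stand for a stronger effect at the one concentration tested and lower numbers for a weaker effect. Compound 1 stands second highest of the three; compound 2 lies above it by a margin beyond the scatter, and compound 3 lies far below it, also beyond the scatter. Going by the values given here, the three compounds differ from one another in more than one place, so no single step between them can be read as a clean comparison.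

Compound 4 `Nc1ccccc1NC(=O)c1ccc(CNc2nc(Cl)nc3c2ncn3Cc2ccccc2)cc1` has not yet been measured. It differs from compound 1 in one place: benzyl in place of sec-butyl on an aromatic nitrogen. No measured pair isolates this change, so its effect is not known from the numbers shown. Because compound 1 already gives 67.7% in this assay, a step of modest size is expected from compound 1 to compound 4, estimated as a number 2.3 percentage points higher from compound 1 to compound 4 (within the scatter), with no strong reason to expect a direction beyond the scatter. Compound 4 is estimated to give 70%, within a range from 50% to 86%.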

Compound 4, a percentage reported as inhibition, at one concentration (the size of the read-out at that concentration, not a potency): 46.4%
The estimate for compound 4 lay 23.6 percentage points above the measured number, and the stated range ends above it.
By their numbers in this assay, from the lowest: compound 3; then compound 4; then compound 1; then compound 2.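

This is the first comparison among the compounds shown that isolates a single place: in this assay, benzyl in place of sec-butyl on the aromatic nitrogen gives a number 21.3 percentage points lower from compound 1 to compound 4 (beyond the scatter). The substituent on this nitrogen is therefore not a neutral choice on the core of compound 1, and here the larger group, the one carrying an aromatic ring, goes with the weaker effect at the one concentration tested. No measurement shown offers an explanation for this drop.

The compounds shown leave open how a methyl group, a longer chain such as n-pentyl, or a cyclopentyl ring would read on this nitrogen. They also leave open whether the same swap gives a similar step when the rest of the molecule is different, since this single pair is the only view of it.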